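Bulkier Aryl Ester Group on a Shared Pyrazole Core

The compounds below may be only part of what the source reports. "The series", "measured", "known", "first", "only" and "open" are said of these compounds alone.

In a functional assay on Raji cells (Homo sapiens) for cytotoxicity, read by MTT assay, with a stated time of 48 h (on this read-out higher numbers stand for weaker inhibition and lower numbers for stronger inhibition), compound 3 `COc1ccc(OC(=O)c2cn(-c3ccccc3)nc2-c2ccncc2)cc1` stops at the limit > 100000 nM, so its real potency is not pinned down. Compound 1 `COc1ccc(OC(=O)c2cn(-c3ccccc3)nc2-c2cccnc2)cc1` likewise stops at the limit > 100000 nM. Thus a step that the two limits leave unreadable from compound 1 to compound 3. Compound 2 `CC(C)(C)c1ccc(OC(=O)c2cn(-c3ccccc3)nc2-c2cccnc2)cc1` gives 42300 nM in this assay, and an at least 2.3-fold lower number from compound 1 to compound 2 (0.37 log units; beyond the scatter). Compound 4 `Cc1ccc(C(C)C)c(OC(=O)c2cn(-c3ccccc3)nc2-c2ccncc2)c1` differs from compound 3 by 2-isopropyl-5-methylphenyl in place of 4-methoxyphenyl on an oxygen next to a carbonyl group. For the measured compounds named here, the only measured step that bears on this is the one where tert-butyl replaced methoxy on the same ring; meanwhile the limit of > 100000 nM in this assay, at which 2 of the 3 values shown sit, leaves two of the three values unreadable. A similar modest gain is expected here, so compound 4 is expected to show an at least 2.0-fold lower number from compound 3 to compound 4 (0.30 log units; that floor lies within the scatter). The estimate for compound 4 is 50000 nM, with a range from 15000 nM to 150000 nM.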

Compound 4, half-maximal inhibitory concentration: 10600 nM
Compound 4: middle estimate off by 4.7-fold (0.67 log units), on the high side; measured number below the stated range.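

Placing 2-isopropyl-5-methylphenyl in place of 4-methoxyphenyl on this oxygen gives an at least 9.4-fold lower number from compound 3 to compound 4 (0.97 log units; beyond the scatter). The aryl group here therefore moves the number in this assay with pyridin-4-yl on the core too, not only with the pyridin-3-yl of compound 2. The true size of this step stays unknown because compound 3 stands at a limit: the limit of > 100000 nM in this assay, at which 2 of the 4 values shown sit.

The compounds shown leave open whether the isopropyl or the methyl accounts for the change, and whether an amine or a carboxylic acid on this aryl ring would lower the number further.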